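Acetyl for Methyl on the Saturated-Chain Analogue

A few compounds are considered here, and "the series" means these few. Any claim that something is new, unique, unknown or untested is made for them only; others in the source may bear on it.

Of the compounds shown here, three built on one shared core have been measured in a physicochemical assay for solubility, read by HPLC, at pH 2; a lower number here means a less soluble compound, a higher number a more soluble compound. Compound 1 `COCc1cc(N)c(Nc2ccc(C#N)cc2)cc1Oc1c(C)cc(/C=C/C#N)cc1C` gives 1.7 ug/mL. Compound 2 `CC(=O)OCc1cc(N)c(Nc2ccc(C#N)cc2)cc1Oc1c(C)cc(/C=C/C#N)cc1C` differs from compound 1 by acetyl in place of methyl on an oxygen on a saturated carbon, and in this assay compound 2 gives 1.87 ug/mL; the step of a 1.1-fold higher number from compound 1 to compound 2 (0.04 log units; within the scatter) lies within the scatter. Compound 3 `COCc1cc(N)c(Nc2ccc(C#N)cc2)cc1Oc1c(C)cc(CCC#N)cc1C` differs from compound 1 at the core by 2-cyanoethyl in place of 2-cyanoethenyl on an aromatic carbon, and in this assay compound 3 gives 1.82 ug/mL, so that the step of a 1.1-fold higher number from compound 1 to compound 3 (0.03 log units; within the scatter) is likewise within the scatter. None of the three numbers can be ordered against the others.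

Compound 4 `CC(=O)OCc1cc(N)c(Nc2ccc(C#N)cc2)cc1Oc1c(C)cc(CCC#N)cc1C` has not yet been measured. It stands to compound 3 exactly as compound 2 stands to compound 1: the counted difference is acetyl in place of methyl on an oxygen on a saturated carbon, and the surroundings of the place are described in the same words in both cases, so this is the same change made a second time. Among the compounds with values here, the first instance of this change gave only the small step of a 1.1-fold higher number from compound 1 to compound 2 (0.04 log units; within the scatter), and compound 3 sits at 1.82 ug/mL; on that basis the expectation for compound 4 is a step of a 1.1-fold higher number from compound 3 to compound 4 (0.03 log units; within the scatter). In this assay compound 4 is therefore estimated to give 1.95 ug/mL, with a likely range from 1.1 ug/mL to 3.5 ug/mL.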

Compound 4, solubility: 2.63 ug/mL
Beside the measured number, compound 4's estimate is 1.3-fold (0.13 log units) below it; low and high end bracket the measured number.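

In this assay, acetyl in place of methyl on an oxygen on a saturated carbon gives a 1.4-fold higher number from compound 3 to compound 4 (0.16 log units; within the scatter) on the core carrying 2-cyanoethyl, and the same change gave a 1.1-fold higher number from compound 1 to compound 2 (0.04 log units; within the scatter) on the core carrying 2-cyanoethenyl, so in both instances the step stays within the scatter. The other change, read on the acetyl compounds, gives a 1.4-fold higher number from compound 2 to compound 4 (0.15 log units; within the scatter) and also stays within the scatter, so the four compounds cannot be ordered by these steps, and carrying the acetyl change from one core to the other shows agreement only in that neither step can be told from repeat measurement. It does not show that the change is without consequence in general, nor that the two steps differ or match in size, and no measurement at hand bears on why the numbers fall where they do.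

The compounds shown leave open whether a group other than methyl or acetyl on that oxygen, such as a chain carrying an amine or a carboxylic acid, would give a step beyond the scatter on either core. They also leave open whether the acetyl step would stay within the scatter on a core with a longer chain in place of 2-cyanoethyl.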